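Compound 3 to compound 4: cyclopropyl for isopropyl

A few compounds are considered here, and "the series" means these few. Any claim that something is new, unique, unknown or untested is made for them only; others in the source may bear on it.

Measured in a functional assay on HeLa cells (Homo sapiens) for antiproliferative activity, read by MTT assay, with a stated time of 48 h; a lower number here means a stronger inhibitor, a higher number a weaker inhibitor
Compound 1 `COc1ccc(-c2cc3c(cn2)[nH]c(=O)n3-c2cc(OC)c(OC)c(OC)c2)cc1O` gives 490 nM
Compound 2 `CCn1c(=O)n(-c2cc(OC)c(OC)c(OC)c2)c2cc(-c3ccc(OC)c(O)c3)ncc21` gives > 20000 nM
Compound 3 `COc1ccc(-c2cc3c(cn2)n(C(C)C)c(=O)n3-c2cc(OC)c(OC)c(OC)c2)cc1O` gives 4240 nM

The value of compound 2 (> 20000 nM) is a limit and not a number. Among the actual numbers, compound 3 (4240 nM) stands highest, and the nearest value is that of compound 1 (490 nM).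

Compound 4 `COc1ccc(-c2cc3c(cn2)n(C2CC2)c(=O)n3-c2cc(OC)c(OC)c(OC)c2)cc1O` has cyclopropyl in place of isopropyl on an aromatic nitrogen. Among the measured compounds shown here, three measured steps bear on this change, all at that nitrogen. Isopropyl in place of hydrogen gave a modest step (an 8.7-fold higher number from compound 1 to compound 3 (0.94 log units; beyond the scatter)). Ethyl in place of hydrogen gave a large step (an at least 40-fold higher number from compound 1 to compound 2 (1.61 log units; beyond the scatter)). Between the two alkyl groups, the measured step was at least modest (an at least 4.7-fold lower number from compound 2 to compound 3 (0.67 log units; beyond the scatter)), so the choice of group has mattered in this small set. From the compounds shown here alone, none of these steps exchanges isopropyl for cyclopropyl, so the direction remains open and the range must stay wide. Compound 3 (4240 nM) is the closest measured reference. The expected step is small and not beyond the scatter (a 1.2-fold lower number from compound 3 to compound 4 (0.08 log units; within the scatter)). Compound 4 is estimated at 3500 nM (expected range 1000 nM to 14000 nM).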

Compound 4, half-maximal inhibitory concentration: > 20000 nM
Compound 4: only a limit was reported; the forecaster's own chance of this, stated with the estimate: 10%; middle value at least 5.7-fold (0.75 log units) away from the limit.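

In this assay compound 4 gives > 20000 nM, which is a limit of the assay and not a number. Cyclopropyl in place of isopropyl on the aromatic nitrogen keeps the count of heavy atoms, yet the change is not neutral, with an at least 4.7-fold higher number from compound 3 to compound 4 (0.67 log units; beyond the scatter), so this position separates two groups of equal size by that count, and isopropyl in compound 3 remains the only one of the three alkyl groups with a readable number. Against the unsubstituted compound, cyclopropyl gives an at least 40-fold higher number from compound 1 to compound 4 (1.61 log units; beyond the scatter), so all three groups shown on this nitrogen go with a higher number than hydrogen, and the step from compound 2 to compound 4 cannot be read: the limit of > 20000 nM in this assay, at which 2 of the 4 values shown sit.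

From the compounds shown here alone, how far compound 2 and compound 4 lie past that limit stays open, and with it any order between ethyl and cyclopropyl. Also open, going by these compounds, is whether methyl, or a longer chain ending in an amine or a carboxylic acid, on this nitrogen would come closer to compound 1 at 490 nM.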